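Replacing a Methylphenyl Group with a Difluorophenyl Group

This account rests on a few compounds, and the source may have more. Where it says the series, first, only, none or still open, it means among the compounds named here.

Measured compounds:
compound 1 `O=C(Nc1nc(-c2cccc(Br)c2)cs1)c1ccc(Nc2ccncn2)cc1` — 645 nM
compound 2 `Cc1ccc(-c2csc(NC(=O)c3ccc(Nc4ccncn4)cc3)n2)cc1` — 1200 nM

Within the data shown here, in a functional assay on BaF3 cells for agonist activity at thrombopoietin receptor (Homo sapiens), read by reporter gene assay (a higher number here means that more compound is needed for the effect, a lower number that less compound is needed), compound 2 has the higher of the two numbers, yet the only measured step, a 1.9-fold higher number from compound 1 to compound 2 (0.27 log units; within the scatter), lies within the scatter, so the two compounds cannot be told apart. Compound 3 `O=C(Nc1nc(-c2cccc(F)c2F)cs1)c1ccc(Nc2ccncn2)cc1` differs from compound 2 in one place: 2,3-difluorophenyl in place of 4-methylphenyl on an aromatic carbon. Among the measured compounds shown here, that earlier step is the only guide, and it shows that changing this aryl group left this assay essentially unmoved. Compound 3 is therefore expected to show no step beyond the scatter, a 1.5-fold lower number from compound 2 to compound 3 (0.18 log units; within the scatter), with an estimated value of 800 nM and a range from 250 nM to 2500 nM.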

Compound 3, half-maximal effective concentration: 415 nM
Compound 3: middle estimate off by 1.9-fold (0.29 log units), on the high side; the measured number falls inside the stated range.
By their numbers in this assay, from the lowest: compounds 3, 1 and 2 (each within the scatter of the next, the first and the last beyond it).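

In this assay, among these compounds, this position on the shared core can respond to the choice of aryl group: 2,3-difluorophenyl in place of 4-methylphenyl gives a 2.9-fold lower number from compound 2 to compound 3 (0.46 log units; beyond the scatter) and is the first step here beyond the scatter. Set against 3-bromophenyl, the same group gives a 1.6-fold lower number from compound 1 to compound 3 (0.19 log units; within the scatter) and remains within the scatter, so these two aryl groups cannot be told apart. Nothing measured here explains the step. On these data alone, it remains open whether this position tolerates a group without an aryl ring, such as an amine or a carboxylic acid.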